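Hydrazone aryl variation in the shared core, step to compound 4

A few compounds are considered here, and "the series" means these few. Any claim that something is new, unique, unknown or untested is made for them only; others in the source may bear on it.

Three members of the series share a core and differ only in the aryl group on a carbon with a double bond to nitrogen. In a functional assay on HT-29 cells (Homo sapiens) for cytotoxicity, read by MTT assay, with a stated time of 72 h (a higher number here means a weaker inhibitor, a lower number a stronger inhibitor), compound 1 `CN(C)CCn1cnnc1-c1cc(Oc2ccc(NC(=O)N/N=C/c3cccc(O)c3)cc2F)ccn1` gives 330 nM, compound 2 `CN(C)CCn1cnnc1-c1cc(Oc2ccc(NC(=O)N/N=C/c3ccc(O)c(Br)c3)cc2F)ccn1` gives 450 nM, and compound 3 `Cc1cc(/C=N/NC(=O)Nc2ccc(Oc3ccnc(-c4nncn4CCN(C)C)c3)c(F)c2)cc(C)c1O` gives 1220 nM. The step of a 1.4-fold higher number from compound 1 to compound 2 (0.13 log units; within the scatter) is within the scatter, whereas a 3.7-fold higher number from compound 1 to compound 3 (0.57 log units; beyond the scatter) and a 2.7-fold higher number from compound 2 to compound 3 (0.43 log units; beyond the scatter) are beyond it, so compound 3 has the highest number of the three in this assay, beyond the scatter from both others.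

Compound 4 `COc1cc(/C=N/NC(=O)Nc2ccc(Oc3ccnc(-c4nncn4CCN(C)C)c3)c(F)c2)cc(OC)c1OC` is the next step from compound 3: 3,4,5-trimethoxyphenyl in place of 4-hydroxy-3,5-dimethylphenyl on a carbon with a double bond to nitrogen. Going by the values given here, both measured steps leading to compound 3 changed the aryl group while keeping one hydrogen-bond donor and both raised the number modestly; no measured step covers replacing the donor with three acceptors. In this assay a modest further rise, or none beyond the scatter, is expected for compound 4, a step of a 1.5-fold higher number from compound 3 to compound 4 (0.17 log units; within the scatter). The estimate for compound 4 in this assay is 1800 nM, within 700 nM to 4500 nM.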

Compound 4, half-maximal inhibitory concentration: 3620 nM
Compound 4: middle estimate off by 2.0-fold (0.30 log units), on the low side, and the stated range covers the measured number.
By their numbers in this assay, from the lowest: compounds 1 and 2 (each within the scatter of the next); then compound 3; then compound 4.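

In this assay, 3,4,5-trimethoxyphenyl is the only aryl group shown on this carbon with 0 hydrogen-bond donors, and the step of a 3.0-fold higher number from compound 3 to compound 4 (0.47 log units; beyond the scatter) shows that this exchange raises the number beyond the scatter. Measured against the other two hydroxyl-bearing aryl groups, the rise is greater, with an 8.0-fold higher number from compound 2 to compound 4 (0.91 log units; beyond the scatter) and an 11-fold higher number from compound 1 to compound 4 (1.04 log units; beyond the scatter), the last being the only large step in the series shown. No measurement at hand explains this rise.

Compound 4 alone lacks a hydroxyl group, so the loss of the donor cannot be separated from the gain of the methoxy groups. Going by these compounds, it remains open whether a 3-methoxyphenyl or 3-aminophenyl group on a carbon with a double bond to nitrogen would stay near compound 1 at 330 nM.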